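Replacing Propanoylamino with Aminomethyl

A few compounds are considered here, and "the series" means these few. Any claim that something is new, unique, unknown or untested is made for them only; others in the source may bear on it.

In a functional assay, with a stated time of 15 min (on this read-out lower numbers stand for an effect already at smaller amounts and higher numbers for an effect only at larger amounts of compound), compound 1 `CN(C)c1ccc(O)c2ccccc12` gives 18000 nM and compound 2 `CCC(=O)Nc1ccc(O)c2ccccc12` gives 16000 nM, so compound 2 stands level with compound 1. Compound 3 `NCc1ccc(O)c2ccccc12` carries aminomethyl in place of propanoylamino on an aromatic carbon, para to a hydroxy group (aminomethyl in place of propanoylamino on an aromatic carbon). Among the measured compounds shown here, only one measured step bears on this change: a 1.1-fold lower number from compound 1 to compound 2 (0.05 log units; within the scatter), a swap of dimethylamino for propanoylamino on that same carbon. This single step says nothing directly about aminomethyl, so the range stays wide. In this assay the expected step is a 1.1-fold lower number from compound 2 to compound 3 (0.03 log units; within the scatter), none beyond the scatter. For compound 3 the estimated value is 15000 nM, ranging from 5000 nM to 45000 nM.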

Compound 3, half-maximal effective concentration: 260000 nM
For compound 3 the middle estimate is 17-fold (1.24 log units) below the measured one; measured number outside the range, above it.
By their numbers in this assay, from the lowest: compounds 2 and 1 (each within the scatter of the next); then compound 3.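

This carbon on the shared core is not indifferent to what it carries: propanoylamino and dimethylamino stand level in this assay, but aminomethyl brings a 16-fold higher number from compound 2 to compound 3 (1.21 log units; beyond the scatter) and a 14-fold higher number from compound 1 to compound 3 (1.16 log units; beyond the scatter) as well. The level pair therefore hid a real sensitivity to the group at this place. Nothing measured here accounts for this jump.

Three compounds cannot show whether the jump goes with the aminomethyl group itself or with any group of its kind. An aminoethyl chain or a carboxylic acid on the same carbon would test how far it extends.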